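Two inactive analogues and an untested methyl variant

The source may report more compounds than this note shows. Statements on the series, on what has been measured and on what is new or still open speak of the compounds shown alone.

Measured compounds:
compound 1 `O=c1cc(CSc2nc3ccccc3s2)oc2ccc(Cl)cc12` — a functional assay on MDA-MB-435S cells (Homo sapiens) for cytotoxicity, read by MTT assay, with a stated time of 72 h; on this read-out lower numbers stand for stronger inhibition and higher numbers for weaker inhibition: > 25000 nM
compound 2 `Cc1ccc2oc(CSc3nnc(C)s3)cc(=O)c2c1` — this assay: > 25000 nM

Compound 1 stands at the assay limit, as its value of > 25000 nM is a limit, not a number. Compound 2 likewise gives only the limit > 25000 nM. Within the data shown here, both values sit at the limit of > 25000 nM in this assay, at which 2 of the 2 values shown sit, so no step between measured compounds can be read.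

Compound 3 `Cc1ccc2oc(CSc3nc4ccccc4s3)cc(=O)c2c1` differs from compound 1 by methyl in place of chloro on an aromatic carbon. Since compound 1 shows only the limit > 25000 nM, no step beyond the scatter is expected in this assay, a step that the limit leaves unreadable from compound 1 to compound 3. Compound 3 is therefore estimated at 40000 nM, between 15000 nM and 120000 nM, most probably again reported as a limit.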

Compound 3, half-maximal inhibitory concentration: > 25000 nM
Compound 3 gave a limit, no number (the forecaster's own chance of this, stated with the estimate: 85%); the middle value lies beyond the limit too.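

Compound 3, like compound 1, gives only a limit in this assay, so methyl in place of chloro yields no readable step: the limit of > 25000 nM in this assay, at which 3 of the 3 values shown sit.

The compounds shown leave open whether any analogue of this series gives a number rather than a limit in this assay.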